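Chloro substitution on the fused ring of compound 1

The source may report more compounds than this note shows. Statements on the series, on what has been measured and on what is new or still open speak of the compounds shown alone.

Measured so far:
compound 1, `O=c1oc(Nc2ccccc2I)nc2ccccc12`, 14700 nM in an assay on isolated protein for inhibition of complement C1r subcomponent (Homo sapiens), with a stated time of 60 min; on this read-out higher numbers stand for weaker inhibition and lower numbers for stronger inhibition
compound 2, `O=c1oc(Nc2ccccc2I)nc2cccc(Cl)c12`, a limit of > 62500 nM in this assay

Compound 1 gives the only number shown in this assay, 14700 nM. For compound 2 this assay reports only a limit, > 62500 nM, as the limit of > 62500 nM in this assay, at which 1 of the 2 values shown sits, records. Putting a chloro group onto compound 1 in place of a hydrogen on an aromatic carbon gave an at least 4.2-fold higher number from compound 1 to compound 2 (0.62 log units; beyond the scatter).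

Compound 3, `O=c1oc(Nc2ccccc2I)nc2cc(Cl)ccc12`, has not yet been measured in this assay. It differs from compound 1 by chloro in place of hydrogen on an aromatic carbon. Going by the values given here, the one measured step of the same kind, from compound 1 to compound 2, weakened inhibition, but the chloro group there sits at a different place, so it bears on compound 3 only loosely. A weakening of modest size, possibly running into the limit of this assay, is therefore expected, a 2.0-fold higher number from compound 1 to compound 3 (0.31 log units; beyond the scatter). For compound 3 an estimate of 30000 nM is given in this assay, within a range from 10000 nM to 90000 nM.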

Compound 3, half-maximal inhibitory concentration: 900 nM
For compound 3 the middle estimate is 33-fold (1.52 log units) above the measured one; measured number outside the range, below it.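

In this assay, chloro in place of hydrogen on an aromatic carbon can strengthen inhibition, and at this position, meta to a fused ring and para to a fused ring, it gives a 16-fold lower number from compound 1 to compound 3 (1.21 log units; beyond the scatter). The earlier step showed only the opposite direction for the same replacement at another place, with an at least 4.2-fold higher number from compound 1 to compound 2 (0.62 log units; beyond the scatter), so on these three compounds the outcome of adding chloro depends on where it stands and not merely on its presence. The weakening side of this contrast rests on compound 2, which gives only a limit: the limit of > 62500 nM in this assay, at which 1 of the 3 values shown sits.

The compounds shown leave open whether the gain belongs to chloro itself or would also appear with fluoro, methyl, methoxy or an amine at this position. They also leave open whether the step would keep its size if the iodo group shared by all three compounds gave way to hydrogen or a methyl group, or if a second chloro group stood elsewhere on the shared core.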